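Swapping a methoxy for a fluoro on the aryl end

This account rests on a few compounds, and the source may have more. Where it says the series, first, only, none or still open, it means among the compounds named here.

Compound 1, `N#Cc1ccc(NC(=S)N/N=C/c2ccc3ccccc3n2)cc1`, in a functional assay on HT-29 cells (Homo sapiens) for antiproliferative activity, read by sulforhodamine B assay, with a stated time of 72 h (a higher number here means a weaker inhibitor, a lower number a stronger inhibitor), gives 15600 nM.
Compound 2, `COc1cccc(NC(=S)N/N=C/c2ccc3ccccc3n2)c1`, in the same assay gives 82400 nM.

Of the two numbers, compound 2 stands at the higher one, so it is the weaker inhibitor of the pair. Going by the values given here, the only measured step is a 5.3-fold higher number from compound 1 to compound 2 (0.72 log units; beyond the scatter), which shows that changing the aryl group on the thiourea nitrogen can move the number by a modest amount.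

Compound 3, `Fc1cccc(NC(=S)N/N=C/c2ccc3ccccc3n2)c1`, differs from compound 2 by fluoro in place of methoxy on an aromatic carbon. Among the compounds with values here, no measured step carries this exact change, so the expectation leans only on the fact that a change on this ring mattered in the step from compound 1 to compound 2. A move toward a lower number is expected for compound 3, of size a 1.6-fold lower number from compound 2 to compound 3 (0.22 log units; within the scatter), but with wide uncertainty. The estimate for compound 3 is 50000 nM, within 15000 nM to 160000 nM.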

Compound 3, half-maximal inhibitory concentration: 74700 nM
Beside the measured number, compound 3's estimate is 1.5-fold (0.17 log units) below it; low and high end bracket the measured number.
By their numbers in this assay, from the lowest: compound 1; then compounds 3 and 2 (each within the scatter of the next).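

At this spot on the ring, meta to a large group, fluoro in place of methoxy gives a 1.1-fold lower number from compound 2 to compound 3 (0.04 log units; within the scatter) in this assay, so this assay does not tell the two groups apart. Against 4-cyanophenyl, 3-fluorophenyl gives a 4.8-fold higher number from compound 1 to compound 3 (0.68 log units; beyond the scatter), so compound 1 keeps the lowest number of the three whichever of these two 3-substituted rings it is compared with. Nothing measured here accounts for these numbers.

The compounds shown leave open whether the lower number of compound 1 comes from the cyano group itself or from where that group sits on the ring, since 4-cyanophenyl differs from the other two rings in both respects. Going by these compounds, how an amine or a carboxylic acid at this spot on the ring would read also remains open.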